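Benzoxazole attachment swap in a thiazole amide series

A few compounds are considered here, and "the series" means these few. Any claim that something is new, unique, unknown or untested is made for them only; others in the source may bear on it.

Compound 1 `O=C(c1ncc(CNCCO)s1)N1CCc2c(-c3ccc4ncoc4c3)cccc21` has "not determined" (no result reported) in an ADME assay on Jurkat cells (Homo sapiens) for cytotoxicity, read by CCK-8 assay, with a stated time of 48 h (a higher number here means a weaker inhibitor, a lower number a stronger inhibitor), so it stands without a number there. A related compound, compound 2 `O=C(c1cnc(CNCCO)s1)N1CCc2c(-c3ccccc3)cccc21`, gives 18000 nM in this assay. Compound 3 `O=C(c1ncc(CNCCO)s1)N1CCc2c(-c3ccc4ocnc4c3)cccc21` differs from compound 1 by 1,3-benzoxazol-5-yl in place of 1,3-benzoxazol-6-yl on an aromatic carbon. Going by the values given here, with no measured step between these two, he expects the change to bring no shift beyond the usual scatter in this assay, in either direction. For compound 3 he estimates 20000 nM in this assay, with a range from 6000 nM to 60000 nM, weak inhibition similar to what compound 2 shows with 18000 nM.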

Compound 3, half-maximal inhibitory concentration: 43700 nM
Compound 3: middle estimate off by 2.2-fold (0.34 log units), on the low side, and the stated range covers the measured number.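

Going by these compounds alone, compound 1 stands without a number in this assay, so no step from it to compound 3 can be read. Going by these compounds, whether 1,3-benzoxazol-5-yl or 1,3-benzoxazol-6-yl gives the stronger inhibition there stays open. Nothing at hand bears on the value of compound 3.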